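The compounds below may be only part of what the source reports. "The series", "measured", "known", "first", "only" and "open" are said of these compounds alone.

Compound 3 `CCN(CC)c1ccc2cc(C(=O)NN)c(=O)oc2c1` gives 3360 nM in a functional assay on HCT-116 cells (Homo sapiens) for cytotoxicity, read by MTT assay, with a stated time of 72 h (a lower number here means a stronger inhibitor, a higher number a weaker inhibitor), the lowest of the two numbers in this small set, with compound 2 `CCN(CC)c1ccc2cc(C(=O)NO)c(=O)oc2c1` nearest at 37600 nM. Compound 1 `CCN(CC)c1ccc2cc(C(=O)NC3CC3)c(=O)oc2c1` gives only a limit of this assay, > 100000 nM, and that is all that is known of it (the limit of > 100000 nM in this assay, at which 1 of the 3 values shown sits). Every step measured so far turns on the same amide-type nitrogen: an at least 2.6-fold lower number from compound 1 to compound 2 (0.42 log units; beyond the scatter), an at least 29-fold lower number from compound 1 to compound 3 (1.47 log units; beyond the scatter) and an 11-fold lower number from compound 2 to compound 3 (1.05 log units; beyond the scatter). Taken together they show that amino on that nitrogen is favoured over hydroxy and over cyclopropyl, and that the cyclopropyl compound reaches no number at all. Compound 4 `CCN(CC)c1ccc2cc(C(=O)N/N=C(/C)c3cccnc3)c(=O)oc2c1` carries the change (a group of 9 heavy atoms (7 carbon, 2 nitrogen; one six-membered aromatic ring with 1 hetero atom) in place of one nitrogen atom, on an amide-type nitrogen). Among the compounds with values here, no measured step puts a group of this kind on that nitrogen, so the measured steps bear on it only loosely: they mark the amino compound as the best of three and say nothing about what a larger replacement does once the nitrogen-to-nitrogen link is kept and the hydrogen-bond donor is gone. The author therefore expects no step beyond the scatter, a 1.1-fold lower number from compound 3 to compound 4 (0.05 log units; within the scatter), while allowing a wide range either way. Compound 4 is estimated at 3000 nM, between 500 nM and 20000 nM.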

Compound 4, half-maximal inhibitory concentration: > 100000 nM
Compound 4: a limit, no number; the forecaster's own chance of this, stated with the estimate: 15%; middle value at least 33-fold (1.52 log units) from the limit.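

Compound 4 reaches only a limit, and no number, in this assay: the limit of > 100000 nM in this assay, at which 2 of the 4 values shown sit.

On the amide-type nitrogen, the group of 9 heavy atoms in place of amino gives an at least 29-fold higher number from compound 3 to compound 4 (1.47 log units; beyond the scatter), so keeping a nitrogen at that point does not by itself preserve the lowest number in the set. The same group in place of the hydroxy group gives an at least 2.6-fold higher number from compound 2 to compound 4 (0.42 log units; beyond the scatter), which shows that this larger group ranks behind both amino and hydroxy, while the two limits leave the step from compound 1 to compound 4 unreadable, so cyclopropyl and the larger group cannot be ordered.

The compounds shown leave open whether a smaller substituent on the amino group, such as methyl or acetyl, would still give a number in this assay. They also do not separate the part played by the double bond from that of the six-membered aromatic ring, which a saturated amine chain or a phenyl ring in its place on the same nitrogen could address.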